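Thiophene for Phenyl on the Sulfamoyl Analogue

The compounds below may be only part of what the source reports. "The series", "measured", "known", "first", "only" and "open" are said of these compounds alone.

Compound 1, `CC(C)Nc1nc(Nc2ccc(N3CCN(C)CC3)cc2)ncc1/N=C/c1ccccc1`, in a functional assay on HCT-116 cells (Homo sapiens) for antiproliferative activity, read by MTT assay; on this read-out lower numbers stand for stronger inhibition and higher numbers for weaker inhibition: > 100000 nM, a limit of the assay and not a number.
Compound 2, `CC(C)Nc1nc(Nc2ccc(N3CCN(C)CC3)cc2)ncc1/N=C/c1cccs1`, in this assay: > 100000 nM, again a limit of the assay.
Compound 3, `CC(C)Nc1nc(Nc2ccc(S(N)(=O)=O)cc2)ncc1/N=C/c1ccccc1`, in this assay: > 100000 nM, also a limit of the assay.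

The change from compound 1 to compound 2 is thiophen-2-yl in place of phenyl on a carbon with a double bond to nitrogen. The step that the two limits leave unreadable from compound 1 to compound 2 cannot be sized. The cores of compound 1 and compound 3 differ by sulfamoyl in place of 4-methylpiperazin-1-yl on an aromatic carbon, and the step that the two limits leave unreadable from compound 1 to compound 3 is likewise unreadable. All three measured compounds sit at the limit of > 100000 nM in this assay, at which 3 of the 3 values shown sit.

Compound 4, `CC(C)Nc1nc(Nc2ccc(S(N)(=O)=O)cc2)ncc1/N=C/c1cccs1`, has not been measured. It differs from compound 3 by thiophen-2-yl in place of phenyl on a carbon with a double bond to nitrogen, the same change as that from compound 1 to compound 2, at the same place. Among the compounds with values here, the pair compound 1 and compound 2 shows only that this change left both at the limit. The step that the limit leaves unreadable from compound 3 to compound 4 is therefore expected to be small, and compound 4 is estimated to give 150000 nM in this assay, most likely reported again as a limit, between 60000 nM and 400000 nM.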

Compound 4, half-maximal inhibitory concentration: 82100 nM
Estimate against measurement, compound 4: 1.8-fold (0.26 log units) above, within the range that was stated.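

On the sulfamoyl core, thiophen-2-yl in place of phenyl gives an at least 1.2-fold lower number from compound 3 to compound 4 (0.08 log units; that floor lies within the scatter) in this assay, and with thiophen-2-yl kept, sulfamoyl in place of 4-methylpiperazin-1-yl gives an at least 1.2-fold lower number from compound 2 to compound 4 (0.08 log units; that floor lies within the scatter). Both are floors that lie within the scatter, so neither shows a real gain, and the steps among compound 1, compound 2 and compound 3 cannot be read, which leaves the same change on the two cores with no sizes to compare. The compounds show only that this change left neither core far from the top of the readable range, while its true size on either core remains unknown: the limit of > 100000 nM in this assay, at which 3 of the 4 values shown sit.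

From the compounds shown here alone, it remains open whether the change would read differently on a core whose values lie well inside the range of this assay. The compounds shown also leave open what a carboxylic acid or a morpholine in place of sulfamoyl, or a furan-2-yl in place of thiophen-2-yl, would give.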